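Ureido in place of hydroxy on compound 2

The source may report more compounds than this note shows. Statements on the series, on what has been measured and on what is new or still open speak of the compounds shown alone.

In an ADME assay on BHK-21 cells (Mesocricetus auratus) for cytotoxicity, read by MTT assay (on this read-out higher numbers stand for lower toxicity in this test and lower numbers for higher toxicity in this test), compound 1 (`CC(=O)c1ccc2[nH]c(-c3ccccc3)nc2c1`) gives > 100000 nM as a limit of the assay and not a number. Compound 2 (`C/C(=N\O)c1ccc2[nH]c(-c3ccccc3)nc2c1`) gives > 100000 nM as a limit too, so it has no exact position. For compound 3 (`C/C(=N\O)c1ccc2[nH]c(-c3ccc(C(F)(F)F)cc3)nc2c1`) the entry reads "not determined" (no result reported) and offers no result. Within the data shown here, the only measured step is a step that the two limits leave unreadable from compound 1 to compound 2 and it gives no size to carry forward. What remains is the limit of > 100000 nM in this assay, at which 2 of the 3 values shown sit, and no step size can be read from it. Compound 4 (`C/C(=N\NC(N)=O)c1ccc2[nH]c(-c3ccccc3)nc2c1`) carries ureido in place of hydroxy on a double-bonded nitrogen on the shared core. The estimated change is a number no higher from compound 2 to compound 4 (the limit leaves the size open) and so no step beyond the scatter is expected in this assay in either direction. For compound 4 the estimate is 100000 nM with an expected range from 40000 nM to 200000 nM in this test.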

Compound 4, half-maximal cytotoxic concentration: > 100000 nM
Compound 4: a limit, no number (the forecaster's own chance of this, stated with the estimate: 65%); the middle value sits exactly at the limit.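

Among these compounds, compound 1, compound 2 and compound 4 all give only a limit of the assay, so no step among them can be read: the limit of > 100000 nM in this assay, at which 3 of the 4 values shown sit.

The compounds shown leave open whether ureido in place of hydroxy changes the read-out in this assay at all.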